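Lengthening the Amide Chain: What to Expect for Edema

This account rests on a few compounds, and the source may have more. Where it says the series, first, only, none or still open, it means among the compounds named here.

Three measured compounds share one core and differ only at an amide nitrogen on the side chain. Compound 1 `COc1cc2c(cc1OC)C(CC(N)=O)CC2` carries hydrogen there, and in a functional assay on the whole organism (strain Wistar) for inhibition, with Rattus norvegicus as the target, read by paw edema, with stated times of 60 min and 3 h, at a dose of 100 mg/kg by the oral route (a lower number here means less inhibition, a higher number more inhibition at the dose given (going by the name of the read-out)), compound 1 gives 30.4%. Compound 2 `CNC(=O)CC1CCc2cc(OC)c(OC)cc21` carries a methyl, and compound 2 gives 29%. Compound 3 `CCNC(=O)CC1CCc2cc(OC)c(OC)cc21` carries an ethyl, and compound 3 gives 26.1%. Compound 3 holds the lowest of the three numbers, but the steps of a number 1.4 percentage points lower from compound 1 to compound 2 (within the scatter), a number 4.3 percentage points lower from compound 1 to compound 3 (within the scatter) and a number 2.9 percentage points lower from compound 2 to compound 3 (within the scatter) all lie within the scatter, so the three compounds cannot be told apart.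

Compound 4 `CCCNC(=O)CC1CCc2cc(OC)c(OC)cc21` carries the chain one carbon further: methyl in place of hydrogen on a saturated chain carbon, two bonds along the chain from an amide-type nitrogen. The closest comparison is a number 2.9 percentage points lower from compound 2 to compound 3 (within the scatter), where a methyl likewise entered the chain and produced no step beyond the scatter. Nothing here points to a direction, so compound 4 is expected to give about 25% in this assay, within 14% to 36%. The expected step is a number 1.1 percentage points lower from compound 3 to compound 4 (within the scatter).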

Compound 4, a percentage reported as inhibition, in the whole organism at one dose (the size of the read-out at that dose, not a potency): 29%
Compound 4: middle estimate off by 4 percentage points, on the low side; low and high end bracket the measured number.
By their numbers in this assay, from the lowest: compounds 3, 2, 4 and 1 (each within the scatter of the next).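

Carrying the chain on to propyl opens no gap in this assay: the result is a number 2.9 percentage points higher from compound 3 to compound 4 (within the scatter), with no change at the digits printed from compound 2 to compound 4 (within the scatter) and a number 1.4 percentage points lower from compound 1 to compound 4 (within the scatter). Compound 4 therefore joins the others as a fourth compound that cannot be told apart, so hydrogen, methyl, ethyl and propyl on the amide-type nitrogen all read alike here, and the extra carbon shows no trend with chain length that the first three compounds could only hint at. Nothing available explains this lack of response to chain length.

On these data alone, whether a longer chain such as butyl or hexyl, or a ring such as phenyl, on that nitrogen would move the number beyond the scatter remains open. So does what a carboxylic acid or an amine in place of the amide would do on the shared core.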